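This account rests on a few compounds, and the source may have more. Where it says the series, first, only, none or still open, it means among the compounds named here.

Compound 1 `Nc1ncc(Br)c2c1ncn2[C@@H]1C[C@H](O)[C@@H](O)[C@H]1O` and compound 2 `Nc1ncc(I)c2c1ncn2[C@@H]1C[C@H](O)[C@@H](O)[C@H]1O` are the measured pair. In an ADME assay on HepG2 2.2.15 cells (Homo sapiens) for cytotoxicity (on this read-out higher numbers stand for lower toxicity in this test and lower numbers for higher toxicity in this test), compound 1 gives only a limit, > 10000 nM. In this assay compound 2 likewise gives only a limit, > 300000 nM. Compound 2 therefore stands at a limit, and the step that the two limits leave unreadable from compound 1 to compound 2 cannot be sized, resting as it does on the limit of > 10000 nM in this assay, at which 1 of the 2 values shown sits, and (the limit of > 300000 nM in this assay, at which 1 of the 2 values shown sits). Compound 3 `Nc1ncc(Cl)c2c1ncn2[C@@H]1C[C@H](O)[C@@H](O)[C@H]1O` differs from compound 2 by chloro in place of iodo on an aromatic carbon. For the measured compounds named here, no measured step reads on this change, so no step beyond the scatter is expected in this assay. Compound 3 is estimated at 100000 nM, between 10000 nM and 1000000 nM. The expected step is an at least 3.0-fold lower number from compound 2 to compound 3 (0.47 log units; beyond the scatter).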

Compound 3, half-maximal cytotoxic concentration: > 300000 nM
Compound 3 gave a limit, no number (the forecaster's own chance of this, stated with the estimate: 85%); at least 3.0-fold (0.47 log units) between middle value and limit.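

For the compounds shown here, compound 1, compound 2 and compound 3 all give only limits in this assay, so no step among them can be read. The compounds shown leave open whether bromo, iodo and chloro differ at all in this assay.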